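A few compounds are considered here, and "the series" means these few. Any claim that something is new, unique, unknown or untested is made for them only; others in the source may bear on it.

In a functional assay on NCI-H23 cells (Homo sapiens) for antiproliferative activity, read by sulforhodamine B assay (a higher number here means a weaker inhibitor of growth, a lower number a stronger inhibitor of growth), compound 3 `CCCCCCOc1cccc(O)c1C(=O)/C=C/c1ccc(O)cc1` gives > 30000 nM as a limit of the assay, not a number. Compound 1 `COc1cccc(OCCC(C)(C)C)c1C(=O)/C=C/c1ccc(O)cc1` gives > 30000 nM as a limit too. Compound 2 `CC(C)(C)CCOc1cccc(O)c1C(=O)/C=C/c1ccc(C(=O)O)cc1` gives 4770 nM as a measured number. Compound 4 `CC(C)=CCOc1cccc(O)c1C(=O)/C=C/c1ccc(O)cc1` differs from compound 3 by a single change: 2-methylprop-1-en-1-yl in place of pentyl on a saturated chain carbon bound to an oxygen on an aromatic ring; in words, 2-methylprop-1-en-1-yl in place of pentyl on a saturated chain carbon bound to an oxygen on an aromatic ring. For the measured compounds named here, no measured step covers this change, so no shift beyond the scatter is expected in this assay and the estimated at least 1.2-fold lower number from compound 3 to compound 4 (0.07 log units; that floor lies within the scatter) should stay small. Compound 4 is estimated at 25000 nM within a range of 9000 nM to 45000 nM and may well report only a limit.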

Compound 4, concentration for 50% growth inhibition: > 30000 nM
Compound 4: a limit, no number (the forecaster's own chance of this, stated with the estimate: 60%); middle value at least 1.2-fold (0.07 log units) away from the limit.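

Compound 3 and compound 4 both report only a limit in this assay, so no step can be read between them: the limit of > 30000 nM in this assay, at which 3 of the 4 values shown sit. As far as these compounds go, how hexyl and 3-methylbut-2-en-1-yl compare on the shared core in this assay remains open.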